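This account rests on a few compounds, and the source may have more. Where it says the series, first, only, none or still open, it means among the compounds named here.

Measured so far:
compound 2 `C[C@H]1CN(c2ncc(C(=N)N)cc2Cl)CCN1C1CCN(Cc2ccc(Cl)cc2)CC1`, 80 nM
compound 1 `CNC(=O)c1cnc(N2CCN(C3CCN(Cc4ccc(C)cc4)CC3)[C@@H](C)C2)c(Cl)c1`, 87 nM

In a functional assay for antagonist activity at C-X-C chemokine receptor type 3 (Homo sapiens) (a lower number here means a stronger inhibitor, a higher number a weaker inhibitor), compound 2 gives 80 nM, the lowest of the two numbers; compound 1 gives 87 nM in this assay, a gap within the scatter, so no order between them is claimed. Compound 3 `C[C@H]1CN(c2ncc(C(=O)Nc3ccc(F)c(F)c3)cc2Cl)CCN1C1CCN(Cc2ccc(Cl)cc2)CC1` differs from compound 2 by a group of 11 heavy atoms (7 carbon, 1 nitrogen, 1 oxygen, 2 fluorine; one six-membered aromatic ring of carbon only) in place of a group of 3 heavy atoms (1 carbon, 2 nitrogen; no ring), on an aromatic carbon. Going by the values given here, no measured step of this kind exists. The change is expected to leave the number within the scatter or lower it modestly; the expected step is a 1.6-fold lower number from compound 2 to compound 3 (0.20 log units; within the scatter). Compound 3 is estimated at 50 nM, with a range from 15 nM to 200 nM.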

Compound 3, half-maximal inhibitory concentration: 22 nM
Estimate against measurement, compound 3: 2.3-fold (0.36 log units) above; measured number inside the range.
By their numbers in this assay, from the lowest: compound 3; then compounds 2 and 1 (each within the scatter of the next).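

In this assay, the (3,4-difluorophenyl)carbamoyl group on this aromatic carbon, para to a large group, gives a 3.6-fold lower number from compound 2 to compound 3 (0.56 log units; beyond the scatter) and is the only step shown in the series. This position therefore tolerates a group of 11 heavy atoms with an aromatic ring, and the number falls rather than rises. Nothing measured here accounts for the step.

The compounds shown do not separate the contribution of the amide link from that of the two fluorines on the ring. A plain phenyl amide, a benzyl amide or a carboxylic acid at this carbon would bear on that.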